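Oxime to Benzoyl on a Triazole Thioether Series

The source may report more compounds than this note shows. Statements on the series, on what has been measured and on what is new or still open speak of the compounds shown alone.

Measured compounds:
compound 1 `C=CCn1c(SC/C(=N\O)c2ccccc2)nnc1-c1ccc(OC)c(OC)c1` — 58%
compound 2 `COc1ccc(-c2nnc(SC/C(=N/O)c3ccccc3)n2-c2ccccc2)cc1` — 63%
compound 3 `CCn1c(SCC(=O)c2ccccc2)nnc1-c1ccc(OC)cc1` — 67%

Three compounds have been examined in a functional assay on the whole organism (strain albino) for inhibition, with Rattus norvegicus as the target, read by paw edema, with a stated time of 3 h, at a dose of 0.28 mmol/kg by the oral route; a higher number here means more inhibition at the dose given (going by the name of the read-out), a lower number less inhibition. Compound 1 gives 58% in this assay, the lowest of the three numbers; the nearest is compound 2 with 63% and the furthest is compound 3 with 67%, yet both of those gaps lie within the usual scatter, so no order among the three can be claimed.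

Compound 4 `C=CCn1c(SCC(=O)c2ccccc2)nnc1-c1ccc(OC)c(OC)c1` has not yet been measured in this assay. It differs from compound 1 in one place: a group of 8 heavy atoms (7 carbon, 1 oxygen; one six-membered aromatic ring of carbon only) in place of a group of 9 heavy atoms (7 carbon, 1 nitrogen, 1 oxygen; one six-membered aromatic ring of carbon only), on a saturated chain carbon bound to a sulfur. Among the measured compounds shown here, no pair of measured compounds shows this exact change on its own, so the size of the step has to be guessed. Compound 3 already carries a benzoyl group on that chain carbon and gives 67%, a number within the scatter of compound 1, which suggests nothing beyond the scatter here. Compound 4 is therefore expected to give about 63% in this assay, with a likely range from 50% to 75%. The estimated step from compound 1 to compound 4, a number 5 percentage points higher from compound 1 to compound 4 (within the scatter), is expected to stay within the scatter.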

Compound 4, a percentage reported as inhibition, in the whole organism at one dose (the size of the read-out at that dose, not a potency): 64%
Compound 4: the middle estimate sits 1 percentage points below what was measured; measured number inside the range.
By their numbers in this assay, from the lowest: compounds 1, 2, 4 and 3 (each within the scatter of the next).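

In this assay, among the compounds shown here, the first direct reading of this place shows that putting benzoyl in place of the group of 9 heavy atoms, on a saturated chain carbon bound to a sulfur, gives a number 6 percentage points higher from compound 1 to compound 4 (within the scatter). The hydrogen-bond donor of the leaving group is absent from benzoyl, and the read-out at this single dose shows no step beyond the scatter with that donor gone. Nothing available here bears on why the step has this size.

The compounds shown leave open whether any group at this place, such as an amine or a carboxylic acid on the chain in place of benzoyl, would move the number beyond the scatter. They also leave open whether the same exchange gives a similar step when the other groups on the shared core differ.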